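Working notes: compound 2 to compound 4, cell tolerance

The source may hold more compounds than are shown below. What is called first, only, known or untested is meant among the compounds shown, and "the series" means these compounds.

Of the compounds shown here, three of the shared core have been read in an ADME assay on A549 cells (Homo sapiens) for cytotoxicity, read by resazurin assay, with a stated time of 48 h; a higher number here means that more compound is tolerated, a lower number that less compound is tolerated. Compound 1 `CC1(ON(c2ccc(NC(=O)c3cc(Cl)ccc3O)c(Cl)c2)C2(C)CCCC2)CCCC1` gives 18000 nM. Compound 2 `O=C(Nc1ccc(NCc2ccccc2)cc1Cl)c1cc(Cl)ccc1O` gives 19700 nM. Compound 3 `O=C(Nc1ccc(NCc2cc(C(F)(F)F)cc(C(F)(F)F)c2)cc1Cl)c1cc(Cl)ccc1O` gives 92800 nM. Compound 2 stands second highest of the three numbers; its distance to compound 1 lies within the scatter, while compound 3 sits beyond the scatter on the higher side.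

Compound 4 `O=C(Nc1ccc(NCc2cccnc2Cl)cc1Cl)c1cc(Cl)ccc1O` has not been measured in this assay. Against compound 2 it carries one change: 2-chloropyridin-3-yl in place of phenyl on a saturated chain carbon bound to a nitrogen on an aromatic ring. Among the measured compounds shown here, no step between two measured compounds matches this change, so nothing measured tells its size directly. The values of compound 2 and compound 3 show that a different group at this place can shift the number upward, but that pair carries a larger change than the one here. The step to compound 4 is therefore expected to be small, most likely none beyond the scatter, with any lean toward a higher number. For compound 4 in this assay the expected value is 23000 nM, with a range from 10000 nM to 55000 nM. The implied step a 1.2-fold higher number from compound 2 to compound 4 (0.07 log units; within the scatter) is expected to stay within the scatter.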

Compound 4, half-maximal cytotoxic concentration: 101000 nM
Estimate against measurement, compound 4: 4.4-fold (0.64 log units) below; measured number above the stated range.
By their numbers in this assay, from the lowest: compounds 1 and 2 (each within the scatter of the next); then compounds 3 and 4 (each within the scatter of the next).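

Working notes, continued. In this assay, 2-chloropyridin-3-yl in place of phenyl on a saturated chain carbon bound to a nitrogen on an aromatic ring gives a 5.1-fold higher number from compound 2 to compound 4 (0.71 log units; beyond the scatter) as the first single-change step read at this position. A change of one ring here is thus enough to move the number beyond the scatter, and compound 4 at 101000 nM lies within the scatter of compound 3 at 92800 nM even though the two carry different rings. Nothing at hand accounts for the size of this step.

The ring nitrogen and the chlorine enter together in compound 4, so their separate contributions cannot be read. Pyridin-3-yl alone, chlorophenyl alone and a saturated ring such as cyclohexyl at this position remain open.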